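From Cyclopentyl to Ethyl on the Ring Nitrogen

The source may report more compounds than this note shows. Statements on the series, on what has been measured and on what is new or still open speak of the compounds shown alone.

Of the compounds shown here, three sharing one core have been measured in a functional assay on the whole organism for antagonist activity, with Mus musculus as the target; a lower number here means that less compound is needed, a higher number that more compound is needed for the effect. Compound 1 `COc1cc(N)c(Cl)cc1NC(=O)C1CCN(Cc2ccc(F)cc2)CC1` gives 0.6 mg/kg, and compound 2 `COc1cc(N)c(Cl)cc1NC(=O)C1CCN(Cc2cccc(C)c2)CC1` gives 2.4 mg/kg. Compound 3 `COc1cc(N)c(Cl)cc1NC(=O)C1CCN(C2CCCC2)CC1` gives only a limit of the assay, > 10 mg/kg. The step of a 4.0-fold higher number from compound 1 to compound 2 (0.60 log units; beyond the scatter) is modest, whereas an at least 16-fold higher number from compound 1 to compound 3 (1.22 log units; beyond the scatter) and an at least 4.1-fold higher number from compound 2 to compound 3 (0.61 log units; beyond the scatter) both end at the limit of > 10 mg/kg in this assay, at which 1 of the 3 values shown sits. Compound 3 therefore stands at the weak end of the three, known only as a limit.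

Compound 4 `CCN1CCC(C(=O)Nc2cc(Cl)c(N)cc2OC)CC1` differs from compound 3 in one place: ethyl in place of cyclopentyl on an amine nitrogen in a ring. Among the measured compounds shown here, no measured step bears directly on exchanging one non-aromatic group on the ring nitrogen for another. The two steps that touch that nitrogen, an at least 16-fold higher number from compound 1 to compound 3 (1.22 log units; beyond the scatter) and an at least 4.1-fold higher number from compound 2 to compound 3 (0.61 log units; beyond the scatter), show that leaving 4-fluorobenzyl or 3-methylbenzyl for cyclopentyl raised the number sharply. Ethyl brings no ring and fewer heavy atoms than cyclopentyl, so no recovery toward compound 1 is expected, and the step that the limit leaves unreadable from compound 3 to compound 4 is expected to remain within the scatter, with a good chance that compound 4 again returns only a limit. Compound 4 is estimated at 15 mg/kg, with a range from 5 mg/kg to 50 mg/kg.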

Compound 4, dose for half-maximal effect: > 10 mg/kg
Compound 4: a limit, no number; the forecaster's own chance of this, stated with the estimate: 60%; the middle value is on the limit's open side.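

In this assay compound 4 returns > 10 mg/kg as a limit, not a number. The small open group ethyl therefore does no better on the ring nitrogen than the larger ringed cyclopentyl, and replacing the benzyl groups with ethyl gives both an at least 16-fold higher number from compound 1 to compound 4 (1.22 log units; beyond the scatter) and an at least 4.1-fold higher number from compound 2 to compound 4 (0.61 log units; beyond the scatter) as steps beyond the scatter. Compound 3 and compound 4 both end at the limit, so the exchange of cyclopentyl for ethyl cannot be read, and the only non-aromatic groups shown on this nitrogen give no number: the limit of > 10 mg/kg in this assay, at which 2 of the 4 values shown sit.

Going by these compounds, how far past the limit compound 3 and compound 4 lie, and whether they differ at all, stays open. So does whether an unsubstituted benzyl, a longer phenylethyl chain or a hydroxyethyl group on the ring nitrogen would return a number.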